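Swapping an aryl group on a histamine H2 agonist

A few compounds are considered here, and "the series" means these few. Any claim that something is new, unique, unknown or untested is made for them only; others in the source may bear on it.

Measured so far:
compound 1 `COc1ccc(C(C)NC(=O)/N=C(\N)NCCCc2sc(N)nc2C)cc1`: 38 nM
compound 2 `Cc1nc(N)sc1CCCN/C(N)=N/C(=O)NCc1ccco1`: 11.8 nM

Of the compounds shown here, two built on the same core have been tested in a functional assay on Right cardiac atrium for agonist activity at histamine H2 receptor (Cavia porcellus), with a stated time of 30 min, in the presence of a further agent that is not named here; on this read-out lower numbers stand for an effect already at smaller amounts and higher numbers for an effect only at larger amounts of compound. Compound 1 `COc1ccc(C(C)NC(=O)/N=C(\N)NCCCc2sc(N)nc2C)cc1` gives 38 nM, the higher of the two numbers. Compound 2 `Cc1nc(N)sc1CCCN/C(N)=N/C(=O)NCc1ccco1` gives 11.8 nM, and the distance between these two values lies beyond the usual scatter of repeated measurements, so compound 2 acts at smaller amounts than compound 1. Among the measured compounds shown here, no single-point step between measured compounds is available here, as the two differ in more than one place.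

Compound 3 `Cc1nc(N)sc1CCCN/C(N)=N/C(=O)NC(C)c1ccccc1F` has not yet been measured. It differs from compound 1 in one place: 2-fluorophenyl in place of 4-methoxyphenyl on a saturated chain carbon bound to an amide-type nitrogen and a saturated chain carbon. For the measured compounds named here, nothing among the measured compounds tells how the read-out responds to this particular exchange, so no step beyond the scatter is expected in either direction in this assay, though a modest shift to a lower number cannot be ruled out. Compound 3 is therefore expected to give about 30 nM, within a range from 10 nM to 90 nM, which amounts to an estimated step of a 1.3-fold lower number from compound 1 to compound 3 (0.10 log units; within the scatter).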

Compound 3, half-maximal effective concentration: 12.3 nM
The estimate for compound 3 lay 2.4-fold (0.39 log units) above the measured number; the measured number falls inside the stated range.
By their numbers in this assay, from the lowest: compounds 2 and 3 (each within the scatter of the next); then compound 1.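

In this assay, the aryl group on a saturated chain carbon bound to an amide-type nitrogen and a saturated chain carbon turns out to affect the read-out: 2-fluorophenyl in place of 4-methoxyphenyl gives a 3.1-fold lower number from compound 1 to compound 3 (0.49 log units; beyond the scatter), a modest step but one beyond the scatter. Among the compounds shown here, this is the first exchange here made in a single place, so the shift can be tied to this group alone, with the rest of the molecule unchanged; the entering group has 7 heavy atoms and 0 hydrogen-bond acceptors, against 8 heavy atoms and 1 hydrogen-bond acceptor in the group that leaves. Nothing available explains the shift in terms of a measured property of either group.

The exchange alters both the substituent and its number in the group's name, so the compounds shown cannot tell which of the two matters. A 4-fluorophenyl or a 2-methoxyphenyl group at this place would separate the two, and a plain phenyl group would show what the read-out does with neither fluorine nor methoxy present.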